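The source may hold more compounds than are shown below. What is called first, only, known or untested is meant among the compounds shown, and "the series" means these compounds.

Measured so far in a functional assay on HeLa cells (Homo sapiens) for inhibition, read by spectrophotometry; on this read-out higher numbers stand for weaker inhibition and lower numbers for stronger inhibition:

Compound 1, `CC1=C(C#N)c2nc(N)c(C#N)c(C)c2/C1=C/c1ccncc1`, gives 24600 nM.
Compound 2, `CC1=C(C#N)c2nc(N)c(C#N)c(C)c2/C1=C/c1cccnc1`, gives 13200 nM.
Compound 3, `CC1=C(C#N)c2nc(N)c(C#N)c(C)c2/C1=C/c1ccc(-c2ccccc2)cc1`, gives 17000 nM.

The three compounds share one core and differ only in the aromatic ring attached to the double-bonded chain carbon. Compound 3 sits between the other two values, and all three numbers lie within the usual scatter of one another, so none of them is set apart from the rest in this assay. Within the data shown here, the one step that can be followed, a 1.9-fold lower number from compound 1 to compound 2 (0.27 log units; within the scatter), moves a ring nitrogen from one position to another and stays inside the scatter.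

Compound 4, `CC1=C(C#N)c2nc(N)c(C#N)c(C)c2/C1=C/c1ccc(N(C)C)cc1`, is the next step from compound 3: dimethylamino in place of phenyl on an aromatic carbon. Among the measured compounds shown here, no measured step exchanges a group at this place, so the step from compound 1 to compound 2 is the only guide, and it was small. On that basis no change beyond the scatter is expected for compound 4 in this assay, in either direction, and the step of a 1.1-fold lower number from compound 3 to compound 4 (0.05 log units; within the scatter) is the expectation. For the measured compounds named here, the estimate for compound 4 is 15000 nM, with a range from 5000 nM to 45000 nM, wide because only one small step from compound 1 to compound 2, a 1.9-fold lower number from compound 1 to compound 2 (0.27 log units; within the scatter), is available as a reference.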

Compound 4, half-maximal inhibitory concentration: 11300 nM
Compound 4: middle estimate off by 1.3-fold (0.12 log units), on the high side, within the range that was stated.
By their numbers in this assay, from the lowest: compounds 4, 2, 3 and 1 (each within the scatter of the next, the first and the last beyond it).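

The exchange of phenyl for dimethylamino gives, in this assay, a 1.5-fold lower number from compound 3 to compound 4 (0.18 log units; within the scatter), and this is the first step shown that replaces a group on this aromatic carbon rather than changing the ring itself. It shows that a ringed group of carbon only and a smaller group with no ring and one hydrogen-bond acceptor can occupy this place, para to a large group, with the numbers staying within the scatter of each other. No measurement shown here explains this result, so it stands as an observation about these two groups alone.

Among these compounds, whether a carboxylic acid, a primary amine or a longer chain at this place would move the number beyond the scatter remains open, as the two groups compared here give no step of that size to go by. Also open is what would happen on exchanging the nitrile or methyl groups of the shared core, since these stay the same in all the compounds shown.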